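The compounds below may be only part of what the source reports. "The series", "measured", "known", "first", "only" and "open" are said of these compounds alone.

Three compounds share one core and differ only in the aryl group carried by the sulfonyl sulfur. Compound 1 `COc1cc2nc(N3CCN(S(=O)(=O)c4ccc(C)cc4)CC3)nc(N)c2cc1OC` gives 30000 nM in a functional assay on PC-3 cells (Homo sapiens) for inhibition; a higher number here means a weaker inhibitor, a lower number a stronger inhibitor. Compound 2 `COc1cc2nc(N3CCN(S(=O)(=O)c4ccc(OC(F)(F)F)cc4)CC3)nc(N)c2cc1OC` gives 25000 nM in this assay, and the step of a 1.2-fold lower number from compound 1 to compound 2 (0.08 log units; within the scatter) shows that this exchange made no real difference. Compound 3 `COc1cc2nc(N3CCN(S(=O)(=O)c4ccc(N)cc4N)CC3)nc(N)c2cc1OC` gives 67000 nM in this assay, the highest of the three numbers: the steps of a 2.2-fold higher number from compound 1 to compound 3 (0.35 log units; beyond the scatter) and a 2.7-fold higher number from compound 2 to compound 3 (0.43 log units; beyond the scatter) are both modest, and in both the 2,4-diaminophenyl group is the one that enters.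

Compound 4 `COc1cc2nc(N3CCN(S(=O)(=O)c4cc(C(=O)O)c(Cl)cc4Cl)CC3)nc(N)c2cc1OC` has not yet been measured in this assay. Its structure differs from compound 3 in one place: 5-carboxy-2,4-dichlorophenyl in place of 2,4-diaminophenyl on a sulfonyl sulfur. The two measured steps that bear on this change are the ones in which the 2,4-diaminophenyl group arrived, each raising the number modestly; here that group leaves again, and a third aryl group, unlike either of the earlier ones, takes its place. Within the data shown here, the step of a 2.2-fold lower number from compound 3 to compound 4 (0.35 log units; beyond the scatter) is therefore expected to be a modest move downward, no larger than the steps that led to compound 3. Compound 4 is accordingly estimated at 30000 nM in this assay, with a likely range from 10000 nM to 100000 nM.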

Compound 4, half-maximal inhibitory concentration: 52000 nM
Beside the measured number, compound 4's estimate is 1.7-fold (0.24 log units) below it; low and high end bracket the measured number.
By their numbers in this assay, from the lowest: compounds 2, 1, 4 and 3 (each within the scatter of the next, the first and the last beyond it).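

In this assay, the 5-carboxy-2,4-dichlorophenyl group on the sulfonyl sulfur cannot be told apart from the 2,4-diaminophenyl group (a 1.3-fold lower number from compound 3 to compound 4 (0.11 log units; within the scatter)) or from the 4-methylphenyl group (a 1.7-fold higher number from compound 1 to compound 4 (0.24 log units; within the scatter)), although the aryl groups in the first of these pairs differ in their substituents and in heavy-atom count. Against the 4-(trifluoromethoxy)phenyl group, however, the same exchange gives a modest rise (a 2.1-fold higher number from compound 2 to compound 4 (0.32 log units; beyond the scatter)), so compound 3 is no longer the only compound whose number stands modestly above that of compound 2, and a rise of this size at this position is not tied to the 2,4-diaminophenyl group. None of the data given here accounts for these steps.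

Compound 4 brings in a carboxylic acid and two chlorines at once, so the compounds shown cannot assign its number to either, and a phenyl group carrying only a carboxylic acid or only chlorine would be needed to separate them. They also leave open how a non-aromatic group on the sulfonyl sulfur, such as cyclohexyl or a longer alkyl chain, would compare with these aryl groups.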